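The source may hold more compounds than are shown below. What is called first, only, known or untested is meant among the compounds shown, and "the series" means these compounds.

Of the compounds shown here, two sharing one core have been measured so far in an ADME assay on Vero cells (Chlorocebus sabaeus) for cytotoxicity, read by flow cytometry and propidium iodide staining, with a stated time of 72 h (on this read-out higher numbers stand for weaker inhibition and lower numbers for stronger inhibition), where compound 1 `CC(C)(C)c1ccc(S(=O)(=O)n2cnc3ccccc32)cc1` gives 68500 nM and compound 2 `O=[N+]([O-])c1ccc(S(=O)(=O)n2cnc3ccccc32)cc1` gives 347000 nM as the higher of the two numbers. Compound 2 is thus the weaker inhibitor of the pair. Next comes compound 3 `CC(=O)c1ccc(S(=O)(=O)n2cnc3ccccc32)cc1` and its change from compound 2 is acetyl in place of nitro on an aromatic carbon with acetyl in place of nitro on an aromatic carbon, para to a large group. Among the measured compounds shown here, only one measured step bears on this place: a 5.1-fold higher number from compound 1 to compound 2 (0.70 log units; beyond the scatter) is modest and beyond the scatter, with nitro in place of tert-butyl. For the measured compounds named here, no acetyl compound has been measured, so that step shows only that a change here can move the number. Going by the values given here, compound 2 holds the higher of the two values, and a modest move towards a lower number is expected, no larger than a 5.1-fold higher number from compound 1 to compound 2 (0.70 log units; beyond the scatter) as the one measured guide. The estimate is a 1.8-fold lower number from compound 2 to compound 3 (0.26 log units; within the scatter) in this assay as an expected step. For compound 3 the estimated value is 190000 nM with an expected range from 85000 nM to 380000 nM on this reasoning.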

Compound 3, half-maximal inhibitory concentration: 656000 nM
Compound 3: the middle estimate sits 3.5-fold (0.54 log units) below what was measured; measured number outside the range, above it.
By their numbers in this assay, from the lowest: compound 1; then compounds 2 and 3 (each within the scatter of the next).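

In this assay, acetyl in place of nitro on an aromatic carbon, para to a large group, gives a 1.9-fold higher number from compound 2 to compound 3 (0.28 log units; within the scatter), so this swap does not separate the two groups at this position, although one measured step had already shown that a change here can move the number. Acetyl in place of tert-butyl gives a 9.6-fold higher number from compound 1 to compound 3 (0.98 log units; beyond the scatter), and set beside a 5.1-fold higher number from compound 1 to compound 2 (0.70 log units; beyond the scatter) this shows that both replacements of tert-butyl end beyond the scatter from compound 1, which holds the lowest number of the three, while compound 2 and compound 3 stay together within the scatter. Nothing available explains why tert-butyl stands apart from the other two groups.

The compounds shown leave open whether this separation belongs to tert-butyl alone or would also appear with a different group at the same place, such as an amine, a carboxylic acid, a chlorine atom or a longer alkyl chain. They also leave open whether the same groups would behave alike on another aromatic carbon of the ring or with a change elsewhere in the shared core.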